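Swapping 2-fluorophenyl for 4-fluorophenyl in a sulfanyl series

The source may report more compounds than this note shows. Statements on the series, on what has been measured and on what is new or still open speak of the compounds shown alone.

Among the compounds with values here, in a functional assay on BGC-823 cells (Homo sapiens) for antiproliferative activity, read by MTT assay, with a stated time of 24 h (on this read-out lower numbers stand for stronger inhibition and higher numbers for weaker inhibition), compound 2 `Fc1ccccc1CSc1nnc(-c2ccc3c(c2)OCCO3)n1-c1ccccc1` gives 18600 nM, the lower of the two numbers available so far. Compound 1 `Cc1ccc(CSc2nnc(-c3ccc4c(c3)OCCO4)n2-c2ccccc2)cc1`, which carries 4-methylphenyl on a saturated chain carbon bound to a sulfur, gives 44300 nM. Compound 3 `Fc1ccc(CSc2nnc(-c3ccc4c(c3)OCCO4)n2-c2ccccc2)cc1` has not yet been measured. It has the same atoms as compound 2, joined differently: 4-fluorophenyl in place of 2-fluorophenyl on a saturated chain carbon bound to a sulfur. Within the data shown here, only one measured step bears on this change, a 2.4-fold lower number from compound 1 to compound 2 (0.38 log units; beyond the scatter), and it is modest. That step also exchanges 4-methylphenyl for 2-fluorophenyl, so it does not isolate the exchange of 2-fluorophenyl for 4-fluorophenyl. A change no larger than that modest step is therefore expected, leaning slightly upward and possibly staying within the scatter. The expected change is a 1.4-fold higher number from compound 2 to compound 3 (0.15 log units; within the scatter). For compound 3 the estimated value is 26000 nM, with an expected range of 11000 nM to 55000 nM.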

Compound 3, half-maximal inhibitory concentration: > 100000 nM
Compound 3: a limit, no number; the forecaster's own chance of this, stated with the estimate: 3%; middle value at least 3.8-fold (0.58 log units) away from the limit.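

In this assay compound 3 gives no number, only a limit of the assay: the limit of > 100000 nM in this assay, at which 1 of the 3 values shown sits. Exchanging 2-fluorophenyl for 4-fluorophenyl on a saturated chain carbon bound to a sulfur gives an at least 5.3-fold higher number from compound 2 to compound 3 (0.73 log units; beyond the scatter), so two groups with the same atoms are separated beyond the scatter, which the earlier step could not show because it also changed methyl to fluoro. Fluoro in place of methyl on an aromatic carbon gives an at least 2.2-fold higher number from compound 1 to compound 3 (0.35 log units; beyond the scatter), so 4-fluorophenyl also falls on the weaker side of 4-methylphenyl, and among the three compounds only 2-fluorophenyl gives the lowest number.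

The compounds shown leave open how a chlorine, a methoxy group or an amine on that phenyl ring would read at this place. Going by these compounds, how far compound 3 lies past its limit also stays open.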